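Chloro for fluoro on the 2,6-dihalophenyl of compound 2

The source may hold more compounds than are shown below. What is called first, only, known or untested is meant among the compounds shown, and "the series" means these compounds.

Compound 2 `CN(C)/N=C1/CN(CC(=O)Nc2cccc(-c3cnn(C)c3)c2)C(=O)C(Cc2c(F)cccc2F)CN1` and compound 1 `Cc1cccc(C)c1CC1CN/C(=N\N(C)C)CN(CC(=O)Nc2cccc(-c3cnn(C)c3)c2)C1=O` share a core and differ at one place. In an assay on isolated protein for inhibition of kallikrein-7 (Homo sapiens), read by fluorescence, with stated times of 10 min and 30 min (a lower number here means a stronger inhibitor, a higher number a weaker inhibitor), compound 1 gives 5200 nM and compound 2 gives 6900 nM; compound 2 holds the highest of the two numbers, and the step of a 1.3-fold higher number from compound 1 to compound 2 (0.12 log units; within the scatter) lies within the scatter. Compound 3 `CN(C)/N=C1/CN(CC(=O)Nc2cccc(-c3cnn(C)c3)c2)C(=O)C(Cc2c(F)cccc2Cl)CN1` carries chloro in place of fluoro on an aromatic carbon. Among the measured compounds shown here, only the step from compound 1 to compound 2 bears on this change, and it stayed within the scatter, so no step beyond the scatter is expected in this assay in either direction. Compound 3 is therefore estimated at 5500 nM, with a range of 2500 nM to 12000 nM, an expected step of a 1.3-fold lower number from compound 2 to compound 3 (0.10 log units; within the scatter).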

Compound 3, half-maximal inhibitory concentration: 940 nM
The estimate for compound 3 lay 5.9-fold (0.77 log units) above the measured number; measured number outside the range, below it.
By their numbers in this assay, from the lowest: compound 3; then compounds 1 and 2 (each within the scatter of the next).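

In this assay the halogen on this aromatic carbon does matter: chloro in place of fluoro gives a 7.3-fold lower number from compound 2 to compound 3 (0.87 log units; beyond the scatter) and so moves the number beyond the scatter, which the earlier change of 2,6-dimethylphenyl to 2,6-difluorophenyl did not do. The 2-chloro-6-fluorophenyl group also stands apart from the 2,6-dimethylphenyl group, with a 5.5-fold lower number from compound 1 to compound 3 (0.74 log units; beyond the scatter) for that exchange. Nothing measured here accounts for this difference.

Still open, from the compounds shown here alone, is whether a larger halogen such as bromo, or a 2,6-dichlorophenyl group, carries the change further. A 2-chloro-6-methylphenyl group would show whether the chloro needs the remaining fluoro.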